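This account rests on a few compounds, and the source may have more. Where it says the series, first, only, none or still open, it means among the compounds named here.

In a functional assay on MCF7 cells (Homo sapiens) for antiproliferative activity, read by MTT assay, with a stated time of 48 h (a higher number here means a weaker inhibitor, a lower number a stronger inhibitor), compound 1 (`O=[N+]([O-])c1cc(C(F)(F)F)cc([N+](=O)[O-])c1Oc1ccc(Cl)cc1/C=N\OCc1ccccc1`) gives 1220 nM, compound 3 (`O=[N+]([O-])c1cc(C(F)(F)F)cc([N+](=O)[O-])c1Oc1c(Cl)cc(Cl)cc1/C=N\OCc1ccccc1`) gives 1210 nM, and compound 2 (`O=[N+]([O-])c1cc(C(F)(F)F)cc([N+](=O)[O-])c1Oc1ccc(Br)cc1/C=N/OCc1ccccc1Cl`) gives 2840 nM. Compound 3 thus stands level with compound 1 at the low end of these numbers, while the number for compound 2 lies higher, beyond the usual scatter.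

The next change leads from compound 3 to compound 4 (`O=[N+]([O-])c1cc(C(F)(F)F)cc([N+](=O)[O-])c1Oc1c(Cl)cc(Cl)cc1/C=N/OCc1ccccc1Cl`): a group of 11 heavy atoms (8 carbon, 1 nitrogen, 1 oxygen, 1 chlorine; one six-membered aromatic ring of carbon only) in place of a group of 10 heavy atoms (8 carbon, 1 nitrogen, 1 oxygen; one six-membered aromatic ring of carbon only), on an aromatic carbon. The shared core stays as it is, and the group on it gains one chlorine. For the measured compounds named here, no measured step isolates this change. Going by the values given here, the only clean step, a 1.0-fold lower number from compound 1 to compound 3 (0.00 log units; within the scatter), adds a chloro at a different place and stays within the scatter, so it gives no reason to expect the dichloro core of compound 3 to shift the outcome. The nearest guide is the gap between compound 1 at 1220 nM and compound 2 at 2840 nM. Compound 2 carries the same larger group, but it also has a bromo where compound 1 has a chloro, so this gap mixes two changes. In this assay the expected step is therefore a 2.1-fold higher number from compound 3 to compound 4 (0.32 log units; beyond the scatter), towards a higher number and a weaker inhibitor. For compound 4 the estimated value is 2500 nM, with an expected range from 1100 nM to 5500 nM.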

Compound 4, half-maximal inhibitory concentration: 1960 nM
The estimate for compound 4 lay 1.3-fold (0.11 log units) above the measured number, and the stated range covers the measured number.
By their numbers in this assay, from the lowest: compounds 3, 1, 4 and 2 (each within the scatter of the next, the first and the last beyond it).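

In this assay the added chlorine on the group comes with a 1.6-fold higher number from compound 3 to compound 4 (0.21 log units; within the scatter) and this is the first pair shown that reads this change without a swap of bromo for chloro on the core. On the core of compound 3, then, the larger group of 11 heavy atoms cannot be told apart from the group of 10 heavy atoms it replaces. One caution remains: the two structures are also drawn with opposite geometry at the double bond outside the rings, so this single step covers that difference as well as the chlorine.

The compounds shown leave open whether the same exchange would read the same way on the core of compound 1, and whether the two geometries of the double bond differ when the rest of the structure stays fixed. They also leave open what a methoxy group, a fluoro group or an amine would do in the place of this chlorine on the ring.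

No measurement here bears on what lies behind the size of this step.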